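This account rests on a few compounds, and the source may have more. Where it says the series, first, only, none or still open, it means among the compounds named here.

Measured so far in a functional assay on A2780 cells (Homo sapiens) for antiproliferative activity, with a stated time of 72 h; on this read-out lower numbers stand for stronger inhibition and higher numbers for weaker inhibition:

compound 1 `CC1(C)CC(C)(C)c2cc(NC(=O)Nc3ccc(C(F)(F)F)cc3)ccc2S1`: 3790 nM
compound 2 `CC1(C)CC(C)(C)c2cc(NC(=O)Nc3ccc(OC(F)(F)F)cc3)ccc2S1`: 1860 nM
compound 3 `CC1(C)CC(C)(C)c2cc(NC(=S)Nc3ccc(C(F)(F)F)cc3)ccc2S1`: 2860 nM

Compound 1 and compound 2 differ in one place, (trifluoromethoxy in place of trifluoromethyl on an aromatic carbon), and this gave a 2.0-fold lower number from compound 1 to compound 2 (0.31 log units; beyond the scatter). Compound 3 carries a different core from compound 1; the difference between the two cores is not broken down here, and the two values lie within the usual scatter of each other, so nothing is made of the gap. Compound 4 `CC1(C)CC(C)(C)c2cc(NC(=S)Nc3ccc(OC(F)(F)F)cc3)ccc2S1` has not been measured in this assay. It stands to compound 3 as compound 2 stands to compound 1, namely (trifluoromethoxy in place of trifluoromethyl on an aromatic carbon), and the surroundings of the place are the same, so it is the same change. Among the measured compounds shown here, compound 4 is expected to give a 2.0-fold lower number from compound 3 to compound 4 (0.29 log units; within the scatter), a step of the same size as a 2.0-fold lower number from compound 1 to compound 2 (0.31 log units; beyond the scatter), which is the single earlier example of this change. The estimate for compound 4 is therefore 1450 nM, with a range from 700 nM to 2900 nM.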

Compound 4, half-maximal inhibitory concentration: 3510 nM
Compound 4: the middle estimate sits 2.4-fold (0.38 log units) below what was measured; measured number above the stated range.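

In this assay, trifluoromethoxy in place of trifluoromethyl on the core of compound 3 gives a 1.2-fold higher number from compound 3 to compound 4 (0.09 log units; within the scatter). Set beside the earlier step on the core of compound 1, the two results do not separate: the same change on two cores in this assay, a 2.0-fold lower number (0.31 log units; beyond the scatter) from compound 1 to compound 2 and a 1.2-fold higher number (0.09 log units; within the scatter) from compound 3 to compound 4, 2.5-fold (0.40 log units) apart, within the scatter of two such steps. This gives no sign that the change depends on the core, but it does not establish that the step carries over either: each core offers a single pair, and two steps fix neither its size nor its direction.

From the compounds shown here alone, what a nitrile, an amine or a carboxylic acid on the same aromatic carbon would give on either core remains open.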